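Swapping the Aryl Group on the Ring Nitrogen

A few compounds are considered here, and "the series" means these few. Any claim that something is new, unique, unknown or untested is made for them only; others in the source may bear on it.

Compound 2 `Nc1scc(CN2CCN(c3cccnc3)CC2)c1C(=O)c1ccc(Cl)cc1` gives 0% in an assay on CHO cells for displacement of a labelled ligand from adenosine receptor A1 (Homo sapiens), read by scintillation counting, with a stated time of 120 min, tested at 10 uM; a lower number here means less inhibition, a higher number more inhibition at the concentration tested (going by the name of the read-out). It stands level with compound 1 `Nc1scc(CN2CCN(c3ccccc3C(F)(F)F)CC2)c1C(=O)c1ccc(Cl)cc1`, which gives 0%, and with compound 3 `Nc1scc(CN2CCN(c3cccc(F)c3)CC2)c1C(=O)c1cccc(C(F)(F)F)c1`, which gives 0%. Among the compounds with values here, the only step measured between compounds that differ in one place, no change at the digits printed from compound 1 to compound 2 (within the scatter), lies within the scatter. Compound 4 `Nc1scc(CN2CCN(c3c(F)cccc3F)CC2)c1C(=O)c1ccc(Cl)cc1` differs from compound 2 in one place: 2,6-difluorophenyl in place of pyridin-3-yl on an amine nitrogen in a ring. The measured step from compound 1 to compound 2 also exchanged one aromatic group for another on the same ring nitrogen without moving the read-out, and compounds 1 and 3 carry different aryl groups yet give the same value. Compound 4 is expected to show no step beyond the scatter, no change at the digits printed from compound 2 to compound 4 (within the scatter). Compound 4 is therefore estimated at 0%, between -10% and 12%.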

Compound 4, a percentage reported as inhibition, at one concentration (the size of the read-out at that concentration, not a potency): 1%
For compound 4 the middle estimate is 1 percentage points below the measured one; the range from low to high includes it.
By their numbers in this assay, from the lowest: compounds 1, 2, 3 and 4 (each within the scatter of the next).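

In this assay, 2,6-difluorophenyl on the ring nitrogen reads the same within the scatter as pyridin-3-yl (a number 1 percentage points higher from compound 2 to compound 4 (within the scatter)) and as 2-(trifluoromethyl)phenyl (a number 1 percentage points higher from compound 1 to compound 4 (within the scatter)). With the rest of the molecule held fixed, this place now carries three different aromatic groups, one with a ring nitrogen and two of carbon only, and none of them lifts the read-out beyond the scatter. No evidence is at hand that explains this flat result. From the compounds shown here alone, whether a benzyl or methyl group on the same ring nitrogen would lift the read-out remains open.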